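A Hydroxyl Added to a Benzyl-Substituted Nucleoside

The source may hold more compounds than are shown below. What is called first, only, known or untested is meant among the compounds shown, and "the series" means these compounds.

Compound 1 `Cc1ccc(CNc2ncnc3c2ncn3[C@@H]2O[C@H](CO)[C@@H](O)[C@H]2O)cc1` was tested in a functional assay on HL-60 cells (Homo sapiens) for antiproliferative activity, with a stated time of 72 h; a lower number here means a stronger inhibitor, a higher number a weaker inhibitor. In this assay compound 1 gives only a limit, > 166000 nM, and not a number. This is where compound 1 stands: the limit of > 166000 nM in this assay, at which 1 of the 2 values shown sits. Compound 2 `COc1cc(CNc2ncnc3c2ncn3[C@@H]2O[C@H](CO)[C@@H](O)[C@H]2O)cc(OC)c1O` shares the same core, but in this assay compound 2 gives "not determined" (no result reported), so it offers no point of comparison. Compound 3 `Cc1cccc(CNc2ncnc3c2ncn3[C@@H]2O[C@H](CO)[C@@H](O)[C@H]2O)c1O` differs from compound 1 by 2-hydroxy-3-methylphenyl in place of 4-methylphenyl on a saturated chain carbon bound to a nitrogen on an aromatic ring. For the measured compounds named here, no step between measured compounds is available in this assay, so nothing measured shows how such a change moves the read-out. The step is expected to be small, no larger than the usual scatter, and is estimated as an at least 1.1-fold lower number from compound 1 to compound 3 (0.04 log units; that floor lies within the scatter). Compound 3 is therefore expected to remain a weak inhibitor in this assay, estimated at 150000 nM with a range from 50000 nM to 400000 nM, and it may well return only a limit again.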

Compound 3, half-maximal inhibitory concentration: 15000 nM
The estimate for compound 3 lay 10-fold (1.00 log units) above the measured number; the whole stated range lies above it.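

In this assay, replacing 4-methylbenzyl with 2-hydroxy-3-methylbenzyl gives the only true number among the compounds shown, with an at least 11-fold lower number from compound 1 to compound 3 (1.04 log units; beyond the scatter). Compound 1 gives only a limit, so this step is a floor and not an exact size: the limit of > 166000 nM in this assay, at which 1 of the 3 values shown sits. It shows that the read-out responds to a change in the aryl group on this saturated chain carbon bound to a nitrogen on an aromatic ring, which neither compound 1 nor compound 2 could show alone.

Going by these compounds, the change brings in a hydroxyl and alters the place of the methyl in a single step, so it remains open which of the two carries the effect. On these data alone, it is also open whether an amine or a carboxylic acid in place of the hydroxyl would give a similar step.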